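Moving the Fluorine on the Benzyl Arm: Compound 3 to Compound 4

The compounds below may be only part of what the source reports. "The series", "measured", "known", "first", "only" and "open" are said of these compounds alone.

Measured compounds in a functional assay on HepG2 cells (Homo sapiens) for inhibition, read by MTT assay, with a stated time of 48 h, tested at 10 uM; a higher number here means more inhibition of growth at the concentration tested, a lower number less inhibition of growth:
- Compound 1, `O=C(/C=C/c1ccc(OCc2cn(Cc3ccccc3)nn2)cc1)c1ccc([N+](=O)[O-])cc1`, gives "not active" (no number reported).
- Compound 2, `O=C(/C=C/c1ccc(OCc2cn(Cc3cccc(Br)c3)nn2)cc1)c1ccc([N+](=O)[O-])cc1`, gives 13%.
- Compound 3, `O=C(/C=C/c1ccc(OCc2cn(Cc3ccccc3F)nn2)cc1)c1ccc([N+](=O)[O-])cc1`, gives 22%.

Only two of the three measured compounds carry a number in this assay, and compound 1 is reported without one. Between the two numbered compounds the step of a number 9 percentage points higher from compound 2 to compound 3 (within the scatter) lies within the usual scatter of such measurements, so compound 2 and compound 3 cannot be told apart on these data. Compound 3 therefore stands where it stands only in the sense that its number is one of two that are indistinguishable.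

Compound 4, `O=C(/C=C/c1ccc(OCc2cn(Cc3ccc(F)cc3)nn2)cc1)c1ccc([N+](=O)[O-])cc1`, is the next compound. It differs from compound 3 by 4-fluorophenyl in place of 2-fluorophenyl on a saturated chain carbon bound to an aromatic nitrogen. Within the data shown here, the only measured step that bears on this change is the one from compound 2 to compound 3, which also reshuffled the substituent on the same benzyl arm and gave a number 9 percentage points higher from compound 2 to compound 3 (within the scatter), within the scatter. Nothing measured suggests that moving the fluorine should do more. The step from compound 3 to compound 4 is therefore expected to be a number 4 percentage points lower from compound 3 to compound 4 (within the scatter), that is, no change beyond the scatter. Compound 4 is estimated at 18% in this assay, in the range 5% to 32%.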

Compound 4, percent growth inhibition at one concentration: 25%
Compound 4: the middle estimate sits 7 percentage points below what was measured; the range from low to high includes it.
By their numbers in this assay, from the lowest: compounds 2, 3 and 4 (each within the scatter of the next, the first and the last beyond it).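

In this assay, exchanging 2-fluorobenzyl for 4-fluorobenzyl gives a number 3 percentage points higher from compound 3 to compound 4 (within the scatter) and so separates neither isomer from the other, which means that on these data the place of the fluorine on the benzyl arm makes no readable difference, even though the two compounds have the same atoms, joined differently. Among these compounds, compound 4 does, however, supply the first step on this arm that lies beyond the scatter, with a number 12 percentage points higher from compound 2 to compound 4 (beyond the scatter) for the exchange of 3-bromophenyl for 4-fluorophenyl on a saturated chain carbon bound to an aromatic nitrogen, a modest step that shows the number in this assay can respond to this position, although compound 2 and compound 3 remain within the scatter of each other. Nothing available accounts for either step.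

Steps to compound 1 cannot be read, since its entry carries no number. From the compounds shown here alone, what a benzyl arm bearing an amine, a carboxylic acid or a methoxy group would give in this assay remains open, as does the effect of a longer chain in place of the benzyl arm.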